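A few compounds are considered here, and "the series" means these few. Any claim that something is new, unique, unknown or untested is made for them only; others in the source may bear on it.

Measured so far, in an ADME assay on MT4 cells (Homo sapiens) for cytotoxicity, read by MTT assay; a higher number here means that more compound is tolerated, a lower number that less compound is tolerated:
compound 1 `O=C(CSc1nnnn1-c1cccc2ccccc12)N/N=C/c1ccco1`: > 330000 nM, a limit of the assay
compound 2 `COc1ccc(/C=N/NC(=O)CSc2nnnn2-c2cccc3ccccc23)cc1`: > 298000 nM, also a limit of the assay
compound 3 `COc1ccc(/C=N/NC(=O)CSc2nnnn2-c2cccc3ccccc23)c(OC)c1`: 28300 nM

Compound 1 stands at a limit of this assay and not at a number (the limit of > 330000 nM in this assay, at which 1 of the 3 values shown sits). Compound 2 likewise sits at a limit (the limit of > 298000 nM in this assay, at which 1 of the 3 values shown sits). Only compound 3 gives a readable number, and it is the lowest of the three.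

Compound 4 `COc1ccc(O)c(/C=N/NC(=O)CSc2nnnn2-c2cccc3ccccc23)c1` is not yet measured. It differs from compound 1 by 2-hydroxy-5-methoxyphenyl in place of furan-2-yl on a carbon with a double bond to nitrogen. For the measured compounds named here, three measured steps bear on this change. a step that the two limits leave unreadable from compound 1 to compound 2. an at least 11-fold lower number from compound 1 to compound 3 (1.06 log units; beyond the scatter). an at least 10-fold lower number from compound 2 to compound 3 (1.02 log units; beyond the scatter). So a phenyl with a single methoxy left the tolerance at a limit, whereas a phenyl carrying two oxygen substituents dropped it by a large step. Compound 4 likewise carries two oxygen substituents on its phenyl, so a large downward step is expected, an at least 5.5-fold lower number from compound 1 to compound 4 (0.74 log units; beyond the scatter), though the hydroxy in place of one methoxy adds uncertainty. Compound 4 is estimated at 60000 nM, within the range 15000 nM to 330000 nM.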

Compound 4, half-maximal cytotoxic concentration: 4510 nM
Compound 4: the middle estimate sits 13-fold (1.12 log units) above what was measured; the measured number lies below the stated range.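

In this assay, the 2-hydroxy-5-methoxyphenyl group on a carbon with a double bond to nitrogen gives the lowest number of the four compounds, with an at least 73-fold lower number from compound 1 to compound 4 (1.86 log units; beyond the scatter) and an at least 66-fold lower number from compound 2 to compound 4 (1.82 log units; beyond the scatter). The comparison with the other phenyl carrying two oxygen substituents also shows a readable difference, a 6.3-fold lower number from compound 3 to compound 4 (0.80 log units; beyond the scatter). Two oxygen substituents on the phenyl therefore do not set a single level of tolerance: the 2-hydroxy-5-methoxyphenyl and 2,4-dimethoxyphenyl groups give clearly different numbers.

Compound 3 and compound 4 differ both in the hydroxy and in the arrangement of the substituents, so these two changes cannot be separated here. Going by these compounds, it also remains open whether an amine or a carboxylic acid in place of the hydroxy would keep the number this low.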